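Hydroxymethyl to 2-hydroxyethyl on compound 2

The compounds below may be only part of what the source reports. "The series", "measured", "known", "first", "only" and "open" are said of these compounds alone.

In an ADME assay on MT2 cells (Homo sapiens) for cytotoxicity, read by XTT assay, with a stated time of 4 days (a lower number here means that less compound is tolerated, a higher number that more compound is tolerated), compound 2 `Cc1nc(C(NC(=O)C(=O)Nc2ccc(F)c(F)c2)C2CCCCN2)sc1CO` stands at > 87000 nM. That value is a limit and not a number. Compound 1 `Cc1ccc(NC(=O)C(=O)NC(c2nc(C)c(CO)s2)C2CCCCN2)c(F)c1` gives > 109000 nM, again a limit. Compound 3 `Cc1nc(C(NC(=O)C(=O)NC2CCCCCC2)C2CCCCN2)sc1CO` gives > 90000 nM, also a limit. All three values shown are thus limits, so compound 2 has no rank among them.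

Compound 4 `Cc1nc(C(NC(=O)C(=O)Nc2ccc(F)c(F)c2)C2CCCCN2)sc1CCO` differs from compound 2 at one place, on a saturated chain carbon bound to an aromatic carbon: hydroxymethyl in place of hydroxy on a saturated chain carbon bound to an aromatic carbon. Cut one bond further out, this reads hydroxymethyl to 2-hydroxyethyl.

The measured steps are a step that the two limits leave unreadable from compound 1 to compound 2, a step that the two limits leave unreadable from compound 1 to compound 3 and a step that the two limits leave unreadable from compound 2 to compound 3. All of them change the group on an amide-type nitrogen, not this chain, and none has a readable size. For the measured compounds named here, they therefore bear on the present change only loosely, and no measured step touches the hydroxymethyl group itself.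

The starting point remains compound 2 at > 87000 nM, a limit. No step beyond the scatter is expected in this assay, and another limit is the likely report. The expected step is an at least 1.0-fold lower number from compound 2 to compound 4 (0.01 log units; that floor lies within the scatter). For compound 4 the estimated value is 85000 nM, with an expected range from 40000 nM to 130000 nM.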

Compound 4, half-maximal cytotoxic concentration: > 78200 nM
Compound 4: only a limit was reported; the forecaster's own chance of this, stated with the estimate: 80%; the middle value is on the limit's open side.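

In this assay compound 4 gives > 78200 nM, a limit. Compound 2 gives > 87000 nM, also a limit. No step can be read between compound 2 and compound 4. The compounds shown leave open where the half-maximal cytotoxic concentration of any of them lies, and whether hydroxymethyl to 2-hydroxyethyl shifts it at all.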